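The source may hold more compounds than are shown below. What is called first, only, known or untested is meant among the compounds shown, and "the series" means these compounds.

Compound 2, `CC/C(=C(/c1ccc(/C=C/C(=O)O)cc1)c1ccc2[nH]ncc2c1C)c1ccccc1`, stands at the lower end of the two numbers in hand: in a functional assay on MCF7 cells (Homo sapiens) for cytotoxicity, read by CellTiter-Glo, with a stated time of 5 days (a higher number here means a weaker inhibitor, a lower number a stronger inhibitor), compound 2 gives 50 nM, while compound 1, `CC/C(=C(/c1ccc(/C=C/C(=O)O)cc1)c1cnc2[nH]ncc2c1)c1ccccc1`, gives 302 nM in this assay. Within the data shown here, the one measured step, a 6.0-fold lower number from compound 1 to compound 2 (0.78 log units; beyond the scatter), replaced the whole aromatic bicycle on the double-bonded chain carbon and so does not speak to the change now at hand.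

Compound 3, `CC/C(=C(/c1ccc(/C=C/C(=O)O)cc1)c1cc2cn[nH]c2cc1C)c1ccccc1`, keeps every atom of compound 2 and differs only in how they are joined: 6-methyl-1H-indazol-5-yl in place of 4-methyl-1H-indazol-5-yl on a double-bonded chain carbon bound to an aromatic carbon and a double-bonded chain carbon. The methyl thus moves from one place on the six-membered ring of the indazole to another, with the ring itself, its hydrogen-bond donor and acceptor, and its attachment unchanged. Among the measured compounds shown here, no measured pair shows the effect of moving a methyl around this ring, so the expectation rests on the unchanged bicycle alone.

Compound 3 is therefore expected to land near compound 2, with the estimated step of a 1.6-fold higher number from compound 2 to compound 3 (0.20 log units; within the scatter) lying within or only just beyond the scatter, leaning slightly toward a higher number. Compound 3 is estimated at 80 nM in this assay, in a range from 30 nM to 250 nM.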

Compound 3, half-maximal inhibitory concentration: 468 nM
Compound 3: the middle estimate sits 5.9-fold (0.77 log units) below what was measured; the measured number lies above the stated range.
By their numbers in this assay, from the lowest: compound 2; then compounds 1 and 3 (each within the scatter of the next).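

In this assay the place of the methyl on the indazole turns out to matter: with the same atoms joined differently, 6-methyl-1H-indazol-5-yl in place of 4-methyl-1H-indazol-5-yl gives a 9.4-fold higher number from compound 2 to compound 3 (0.97 log units; beyond the scatter). The low number of compound 2 therefore belongs to the 4-methyl-1H-indazol-5-yl group specifically and not to any methyl-bearing indazole, which the earlier pair could not show because it exchanged the whole bicycle. The second step, a 1.5-fold higher number from compound 1 to compound 3 (0.19 log units; within the scatter), shows that the 6-methyl-1H-indazol-5-yl group brings none of the gain seen with compound 2 over compound 1, and nothing measured on these compounds accounts for the gap between the two methyl placements.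

The compounds shown leave open what the indazole does with no methyl at all, so it cannot be said whether the 4-methyl group lowers the number or the 6-methyl group raises it. They also leave open whether an ethyl group or a chlorine atom in place of the methyl of compound 2 would keep its low number.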